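Replacing 3-methylphenyl with 2,3-dihydro-1H-inden-5-yl on an amine nitrogen

The source may hold more compounds than are shown below. What is called first, only, known or untested is meant among the compounds shown, and "the series" means these compounds.

- compound 1 `CC(=O)c1cccc(N/C(=N/[C@@H]2c3cc(C#N)ccc3OC(C)(C)[C@H]2O)NC#N)c1`: 8400 nM
- compound 2 `Cc1cccc(N/C(=N/[C@@H]2c3cc(C#N)ccc3OC(C)(C)[C@H]2O)NC#N)c1`: 1000 nM

In a functional assay (aorta) with Rattus norvegicus as the target (on this read-out lower numbers stand for stronger inhibition and higher numbers for weaker inhibition), compound 2 gives 1000 nM, the lower of the two numbers. Compound 3 `CC1(C)Oc2ccc(C#N)cc2[C@@H](/N=C(\NC#N)Nc2ccc3c(c2)CCC3)[C@@H]1O` differs from it in one place: 2,3-dihydro-1H-inden-5-yl in place of 3-methylphenyl on an amine nitrogen. Going by the values given here, only one measured step bears on this, and it is modest: an 8.4-fold lower number from compound 1 to compound 2 (0.92 log units; beyond the scatter), with methyl in place of acetyl on an aromatic carbon. That step removed a carbonyl, whereas the present change brings in only carbon, so a smaller step is expected, and none beyond the scatter. The expected change is a 1.3-fold lower number from compound 2 to compound 3 (0.10 log units; within the scatter). For compound 3 the estimate is 800 nM, with an expected range of 250 nM to 2500 nM.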

Compound 3, half-maximal inhibitory concentration: 41300 nM
The estimate for compound 3 lay 52-fold (1.71 log units) below the measured number, and the stated range ends below it.
By their numbers in this assay, from the lowest: compound 2; then compound 1; then compound 3.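

Putting 2,3-dihydro-1H-inden-5-yl in place of 3-methylphenyl gives a 41-fold higher number from compound 2 to compound 3 (1.62 log units; beyond the scatter) in this assay, so a change that adds only carbon on this amine nitrogen can shift the number more than swapping acetyl for methyl did. The new group also trails the 3-acetylphenyl group, with a 4.9-fold higher number from compound 1 to compound 3 (0.69 log units; beyond the scatter). Nothing available explains this loss. On these data alone, whether the closed five-membered ring or the added carbon alone accounts for the change stays open, as does how 3,4-dimethylphenyl or plain phenyl would read on this amine nitrogen.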